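The source may report more compounds than this note shows. Statements on the series, on what has been measured and on what is new or still open speak of the compounds shown alone.

Of the compounds shown here, three sharing one core have been measured in a physicochemical assay for solubility, read by spectrophotometry, in phosphate buffer, with a stated time of 18 h, at pH 7.4; a lower number here means a less soluble compound, a higher number a more soluble compound. Compound 1 `CCc1ccc(-c2nc3c(c(C)nn3-c3ccccc3)c(-c3ccccc3O)c2C#N)cc1` gives (3100 nM), compound 2 `CCc1ccc(-c2nc3c(c(C)nn3-c3ccccc3)c(-c3ccccc3OC(F)(F)F)c2C#N)cc1` gives (9900 nM), and compound 3 `Cc1nn(-c2ccccc2)c2nc(-c3ccc(F)cc3)c(C#N)c(-c3ccccc3O)c12` gives (6000 nM). The number for compound 3 lies within the scatter of both others. Compound 4 `Cc1nn(-c2ccccc2)c2nc(-c3ccc4c(c3)OCCO4)c(C#N)c(-c3ccccc3O)c12` carries 2,3-dihydro-1,4-benzodioxin-6-yl in place of 4-fluorophenyl on an aromatic carbon. The closest evidence is the change to that same group (a 1.9-fold higher number from compound 1 to compound 3 (0.29 log units; within the scatter)), which stayed within the scatter. The modest step (a 3.2-fold higher number from compound 1 to compound 2 (0.50 log units; beyond the scatter)) concerns a different group and bears on this change only weakly. No step beyond the scatter is therefore expected in this assay. The expected change (a 1.3-fold lower number from compound 3 to compound 4 (0.12 log units; within the scatter)) is small and could fall in either direction. For compound 4 the estimated value is 4500 nM with an expected range from 1800 nM to 11000 nM in this measurement.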

Compound 4, solubility: 11000 nM
Estimate against measurement, compound 4: 2.4-fold (0.39 log units) below; the measured number falls inside the stated range.
By their numbers in this assay, from the lowest: compounds 1, 3, 2 and 4 (each within the scatter of the next, the first and the last beyond it).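

In this assay, 2,3-dihydro-1,4-benzodioxin-6-yl in place of 4-fluorophenyl on this aromatic carbon next to the ring nitrogen gives a 1.8-fold higher number from compound 3 to compound 4 (0.26 log units; within the scatter). Among these compounds, in place of 4-ethylphenyl at the same position, it gives a 3.5-fold higher number from compound 1 to compound 4 (0.55 log units; beyond the scatter), the first step here to pass the scatter, as the fluoro-for-ethyl change did not. No measured evidence accounts for this step. Still open, as far as these compounds go, is whether an amine or a carboxylic acid on this aryl group would shift the number further. Also open, from the compounds shown here alone, is how 2,3-dihydro-1,4-benzodioxin-6-yl behaves together with trifluoromethyl on the phenol oxygen.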